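The source may hold more compounds than are shown below. What is called first, only, known or untested is meant among the compounds shown, and "the series" means these compounds.

Compound 1 `O/N=C(/CCN1CCN(c2ccccn2)CC1)c1ccccc1Cl` carries a chloro group on an aromatic carbon. In a functional assay on HEK293 cells with D(4) dopamine receptor (Homo sapiens) as the target, read by FLIPR (a higher number here means that more compound is needed for the effect, a lower number that less compound is needed), compound 1 gives 25 nM. Compound 2 `Cc1ccccc1/C(CCN1CCN(c2ccccn2)CC1)=N\O` differs from it by methyl in place of chloro on an aromatic carbon, and in this assay compound 2 gives 20.3 nM. That change made a step of a 1.2-fold lower number from compound 1 to compound 2 (0.09 log units; within the scatter). Compound 3 `O/N=C(\CCN1CCN(c2ccccn2)CC1)c1cccc(Cl)c1` has the same atoms as compound 1, joined differently; the difference between the two cores is not broken down here. In this assay compound 3 gives 11.9 nM. Its gap to compound 1 lies beyond the scatter, while its gap to compound 2 lies within it, so no order between compound 3 and compound 2 can be read from these numbers.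

Compound 4 `Cc1cccc(/C(CCN2CCN(c3ccccn3)CC2)=N/O)c1` has not yet been measured. It differs from compound 3 by methyl in place of chloro on an aromatic carbon. Among the measured compounds shown here, this is the same kind of change as the one from compound 1 to compound 2, though not the same: in compound 1 the place is ortho to a large group, whereas in compound 3 it is meta to a large group. For the measured compounds named here, the only guide is the earlier step, and because a 1.2-fold lower number from compound 1 to compound 2 (0.09 log units; within the scatter) lay within the scatter, there is no ground to expect a large shift here. The step from compound 3 to compound 4 in this assay is therefore expected to be about a 1.2-fold lower number from compound 3 to compound 4 (0.08 log units; within the scatter). Compound 4 is estimated at 10 nM, with an expected range from 5 nM to 22 nM.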

Compound 4, half-maximal effective concentration: 2.3 nM
Estimate against measurement, compound 4: 4.3-fold (0.64 log units) above; the whole stated range lies above it.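

In this assay, putting methyl in place of chloro on the aromatic carbon of compound 3 made a clear difference, with a 5.2-fold lower number from compound 3 to compound 4 (0.71 log units; beyond the scatter). Set beside the earlier step, this shows that the size of the change did not carry over from one core to the other, so a step read on one core of this series was a poor guide to the same change on the other: the same change on two cores in this assay, a 1.2-fold lower number (0.09 log units; within the scatter) from compound 1 to compound 2 and a 5.2-fold lower number (0.71 log units; beyond the scatter) from compound 3 to compound 4, 4.2-fold (0.62 log units) apart, beyond the scatter of two such steps What this does not show is why the two steps part, since the pairs offer only two cases, and it gives no rule for how the same change would behave on a third core; only the second step stands clear of the scatter, and nothing here says that methyl in place of chloro lowers the number across the series.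

From the compounds shown here alone, how fluoro, methoxy or an amine on that same aromatic carbon would compare with chloro and methyl stays open, as does the effect of a bare hydrogen there. Also open, going by these compounds, is whether the gap between the two steps would persist on a core with a longer chain, or with a carboxylic acid elsewhere on the molecule.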